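This account rests on a few compounds, and the source may have more. Where it says the series, first, only, none or still open, it means among the compounds named here.

Measured so far:
Compound 1 `CN(C)c1ccc(/C=C2\S/C(=N\c3nc(-c4ccc(Cl)cc4)cs3)NC2=O)cc1`: in a functional assay on SW-620 cells (Homo sapiens) for cytotoxicity, read by MTT assay, with a stated time of 72 h (a higher number here means a weaker inhibitor, a lower number a stronger inhibitor), compound 1 gives 200 nM.
Compound 2 `Cc1ccc(/C=C2\S/C(=N\c3nc(-c4ccc(Cl)cc4)cs3)NC2=O)cc1`: in this assay compound 2 gives 890 nM.

Within the data shown here, compound 2 stands at the higher of the two numbers in this assay; its nearest neighbour is compound 1, and the only measured step, a 4.5-fold higher number from compound 1 to compound 2 (0.65 log units; beyond the scatter), separates the two. Compound 3 `COc1ccc(/C=C2\S/C(=N\c3nc(-c4ccc(Cl)cc4)cs3)NC2=O)cc1` is not yet measured. It differs from compound 2 by methoxy in place of methyl on an aromatic carbon. Among the measured compounds shown here, no measured step exchanges methyl for methoxy at this carbon; the one step that bears on this position, a 4.5-fold higher number from compound 1 to compound 2 (0.65 log units; beyond the scatter), shows that the group on this aromatic carbon moves the number in this assay beyond the scatter. On that basis a modest fall in the number is expected for this change, a 1.8-fold lower number from compound 2 to compound 3 (0.25 log units; within the scatter), with wide uncertainty in both directions. Compound 3 is estimated at 500 nM in this assay, within a range from 200 nM to 1300 nM.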

Compound 3, half-maximal inhibitory concentration: 50 nM
Compound 3: middle estimate off by 10-fold (1.00 log units), on the high side, outside the stated range (below it).
By their numbers in this assay, from the lowest: compound 3; then compound 1; then compound 2.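

In this assay, methoxy in place of methyl at this carbon gives an 18-fold lower number from compound 2 to compound 3 (1.25 log units; beyond the scatter), a large change from a swap that adds only one oxygen to the leaving group's single carbon. Methoxy in place of dimethylamino gives a 4.0-fold lower number from compound 1 to compound 3 (0.60 log units; beyond the scatter), so the earlier step could not have shown that compound 3 is the strongest of the three, with dimethylamino in the middle rather than the best group at this position. Nothing on hand explains this order.

Going by these compounds, it remains open whether a hydroxyl group or a longer alkoxy chain such as ethoxy at this carbon would keep the number of compound 3, and whether a methoxy group on another carbon of this ring would do the same. On these data alone, whether the order of the three holds in other cell lines also remains open.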